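The source may report more compounds than this note shows. Statements on the series, on what has been measured and on what is new or still open speak of the compounds shown alone.

Measured in a toxicity assay on THP-1 cells (Homo sapiens) for inhibition; on this read-out lower numbers stand for higher toxicity in this test and higher numbers for lower toxicity in this test:
- compound 1 `COc1ccc(-c2cnc(NC(=O)c3ncc[nH]3)n2C)cc1`: > 100000 nM (a limit)
- compound 2 `Cn1c(-c2ccccc2Cl)cnc1NC(=O)c1ncc[nH]1`: > 50000 nM (a limit)
- compound 3 `Cn1c(-c2ccc(Cl)cc2)cnc1NC(=O)c1ccc(F)cc1`: 37000 nM

For the measured compounds named here, compound 3 stands alone as the only member of the series with an actual number, 37000 nM. The next compound to be read is compound 4 `Cn1c(-c2ccc(Cl)cc2)cnc1NC(=O)c1ncc[nH]1`, which differs from compound 3 on a carbonyl carbon whose other neighbour is an amide-type nitrogen: 1H-imidazol-2-yl in place of 4-fluorophenyl on a carbonyl carbon.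

Going by the values given here, no measured pair isolates this change, so the expectation rests on the two compounds that already carry 1H-imidazol-2-yl on the carbonyl carbon. Compound 1 has this group, and its value is a limit, > 100000 nM. Compound 2 has it too, and its value is also a limit, > 50000 nM.

A modest rise in this assay is therefore expected, towards lower toxicity in this test, and the read-out may well return only a limit. The expected change is a 1.9-fold higher number from compound 3 to compound 4 (0.28 log units; within the scatter). Compound 4 is estimated at 70000 nM, with an expected range of 35000 nM to 150000 nM.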

Compound 4, half-maximal cytotoxic concentration: 52000 nM
Compound 4: middle estimate off by 1.3-fold (0.13 log units), on the high side; the measured number falls inside the stated range.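

In this assay, 1H-imidazol-2-yl in place of 4-fluorophenyl on a carbonyl carbon gives a 1.4-fold higher number from compound 3 to compound 4 (0.15 log units; within the scatter), so this exchange leaves compound 3 and compound 4 indistinguishable in this test. With 1H-imidazol-2-yl held fixed, chloro in place of methoxy on an aromatic carbon gives an at least 1.9-fold lower number from compound 1 to compound 4 (0.28 log units; that floor lies within the scatter); this is a floor set by a limit, and it too does not clear the scatter. The step from compound 2 to compound 4 cannot be read because compound 2 stands at a limit: the limit of > 50000 nM in this assay, at which 1 of the 4 values shown sits.

On these data alone, it remains open whether a carboxylic acid or an amine on the carbonyl carbon would give a number beyond the scatter. The same holds for a longer alkyl chain on the aromatic carbon that carries chloro in compound 4.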